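A few compounds are considered here, and "the series" means these few. Any claim that something is new, unique, unknown or untested is made for them only; others in the source may bear on it.

Values so far in a physicochemical assay for solubility, in phosphate buffer, with a stated time of 18 h, at pH 7.4 (a lower number here means a less soluble compound, a higher number a more soluble compound), are as follows
Compound 1 (`Nc1cc2c(-n3nc(-c4ccccn4)nc3N)ncnc2cc1Cl`) gives 3000 nM
Compound 2 (`COc1cc2ncnc(-n3nc(-c4ccccn4)nc3N)c2cc1N`) gives 3000 nM

For the measured compounds named here, compound 2, at 3000 nM, stands level with the only other measured compound. Going by the values given here, the one measured step, methoxy in place of chloro on an aromatic carbon, shows no change at the digits printed from compound 1 to compound 2 (within the scatter). The next compound is compound 3 (`COc1cc2ncnc(-n3nc(-c4ccccn4)nc3N)c2cc1OCCCN(C)C`), which carries 3-(dimethylamino)propoxy in place of amino on an aromatic carbon. The measured step swaps a different group, so it says little about this change. Among the compounds with values here, no measured pair replaces the amino group, which leaves the direction uncertain, and only a modest rise in this assay is expected. The estimated step is a 2.7-fold higher number from compound 2 to compound 3 (0.43 log units; beyond the scatter), and a result within the scatter would be no surprise. For compound 3 the expected value is 8000 nM, with an estimated range from 1500 nM to 40000 nM.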

Compound 3, solubility: 53000 nM
Compound 3: middle estimate off by 6.6-fold (0.82 log units), on the low side; the measured number lies above the stated range.
By their numbers in this assay, from the lowest: compounds 1 and 2 (each within the scatter of the next); then compound 3.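

In this assay, putting 3-(dimethylamino)propoxy in place of amino, on the aromatic carbon ortho to a methoxy group, gives an 18-fold higher number from compound 2 to compound 3 (1.25 log units; beyond the scatter). The amino group stays the same in compound 1 and compound 2, and methoxy in place of chloro gave no change at the digits printed from compound 1 to compound 2 (within the scatter), so this is the first change shown that moves the number beyond the scatter. No measurement here explains the rise.

This single swap removes the amino group and brings in an oxygen link, a chain and a dimethylamino end all at once, so the compounds shown cannot separate the share of each part. A plain propoxy chain without the amine, or a morpholine at the chain end, would be needed to tell these parts apart.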